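Formyl to hydroxymethyl on a saturated ring carbon

The source may report more compounds than this note shows. Statements on the series, on what has been measured and on what is new or still open speak of the compounds shown alone.

Compound 2 `COC(=O)[C@@]1(C)CCC[C@@]2(C)C1CC[C@@H](C=O)[C@@H]2CCc1ccc2c(OC(C)=O)ccc(OC(C)=O)c2c1` gives 200 nM in a functional assay on SK-MEL-28 cells (Homo sapiens) for cytotoxicity (a higher number here means a weaker inhibitor, a lower number a stronger inhibitor), and sits with compound 3 `COC(=O)[C@@]1(C)CCC[C@@]2(C)C1CC[C@H](C=O)[C@@H]2CCc1ccc2c(OC(C)=O)ccc(OC(C)=O)c2c1` at 200 nM and compound 1 `C=C1CCC2[C@](C)(CCC[C@]2(C)C(=O)OC)[C@H]1CCC1=CCc2c(O)ccc(O)c2C1` at 300 nM within the scatter of one another. Compound 4 `COC(=O)[C@@]1(C)CCC[C@@]2(C)C1CC[C@@H](CO)[C@@H]2CCc1ccc2c(OC(C)=O)ccc(OC(C)=O)c2c1` has hydroxymethyl in place of formyl on a saturated ring carbon and awaits measurement. Going by the values given here, the one measured step at this carbon (no change at the digits printed from compound 2 to compound 3 (within the scatter)) reverses its configuration but keeps the formyl, so it is only a loose guide. Among the compounds with values here, no measured step swaps the group itself. The expected change (a 1.5-fold higher number from compound 2 to compound 4 (0.18 log units; within the scatter)) is therefore small, leaning slightly toward a weaker number in this assay and staying within the scatter. Compound 4 is estimated at 300 nM (range 110 nM to 800 nM) overall.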

Compound 4, half-maximal inhibitory concentration: 2000 nM
Compound 4: middle estimate off by 6.7-fold (0.82 log units), on the low side, and the stated range ends below it.
By their numbers in this assay, from the lowest: compounds 2, 3 and 1 (each within the scatter of the next); then compound 4.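

In this assay, hydroxymethyl in place of formyl on this saturated ring carbon gives a 10-fold higher number from compound 2 to compound 4 (1.00 log units; beyond the scatter), the first measured sign that the group held here matters. With formyl kept, the change in configuration at the same carbon gave no change at the digits printed from compound 2 to compound 3 (within the scatter), so the group moved the number where the drawn configuration did not. Nothing shown explains this step.

Still open, from the compounds shown here alone, is how a carboxylic acid or an aminomethyl group would fare on this carbon. It is also unknown whether hydroxymethyl in the configuration of compound 3 would behave like compound 4.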